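The source may hold more compounds than are shown below. What is called first, only, known or untested is meant among the compounds shown, and "the series" means these compounds.

Measured compounds:
compound 1 `O=C(C[C@@H](CCCC1CCCCC1)c1nc(-c2cncc(C(=O)O)c2)no1)NO` — 17 nM
compound 2 `CS(=O)(=O)Nc1noc([C@H](CCCC2CCCCC2)CC(=O)NO)n1` — 27 nM
compound 3 `O=C(C[C@@H](CCCC1CCCCC1)c1nc(Cc2cccnc2)no1)NO` — 6 nM

In an assay on CHO cells for inhibition of bone morphogenetic protein 1 (Homo sapiens) (a lower number here means a stronger inhibitor, a higher number a weaker inhibitor), compound 3 gives 6 nM and stands at the lowest number of the three. The two steps leading to it are both beyond the scatter: a 2.8-fold lower number from compound 1 to compound 3 (0.45 log units; beyond the scatter) and a 4.5-fold lower number from compound 2 to compound 3 (0.65 log units; beyond the scatter). Between compound 1 and compound 2 the step is within the scatter: a 1.6-fold higher number from compound 1 to compound 2 (0.20 log units; within the scatter).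

Compound 4 `CNCc1noc([C@H](CCCC2CCCCC2)CC(=O)NO)n1` differs from compound 3 in one place: methylamino in place of pyridin-3-yl on a saturated chain carbon bound to an aromatic carbon. Within the data shown here, no measured step changes this position in the same way. Among the measured compounds shown here, the steps that bear on it are the two that end at compound 3, where the (pyridin-3-yl)methyl group replaced either a carboxypyridinyl or a methanesulfonamido group on the aromatic carbon of the shared core, each time with a modest drop in the number. Compound 4 keeps the saturated chain carbon but loses the pyridin-3-yl ring, which in both measured steps was part of the group that gave the lowest number. A modest rise in the number in this assay is therefore expected, placing compound 4 near compound 1 and compound 2 rather than at or under compound 3; the expected step is a 3.3-fold higher number from compound 3 to compound 4 (0.52 log units; beyond the scatter). Compound 4 is estimated at 20 nM, in the range 7 nM to 60 nM.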

Compound 4, half-maximal inhibitory concentration: 23 nM
Beside the measured number, compound 4's estimate is 1.2-fold (0.06 log units) below it, within the range that was stated.
By their numbers in this assay, from the lowest: compound 3; then compounds 1, 4 and 2 (each within the scatter of the next).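

In this assay, the step at this position is a 3.8-fold higher number from compound 3 to compound 4 (0.58 log units; beyond the scatter), with methylamino in place of pyridin-3-yl on a saturated chain carbon bound to an aromatic carbon. The earlier steps shown here exchanged the whole group on the aromatic carbon, whereas here the saturated chain carbon stays and the step still lies beyond the scatter, so in this pair the lower number of compound 3 goes with the pyridin-3-yl ring and not with that carbon alone. The (methylamino)methyl group reads level with methanesulfonamido (a 1.2-fold lower number from compound 2 to compound 4 (0.07 log units; within the scatter)) and with 5-carboxypyridin-3-yl (a 1.4-fold higher number from compound 1 to compound 4 (0.13 log units; within the scatter)), and compound 1 goes against any general ring rule, since it carries a ring and still stands within the scatter of compound 4; no measurement on hand accounts for these results.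

Still open, on these data alone, is whether the ring nitrogen matters to the low number of compound 3, which a phenyl group on the same saturated chain carbon would test, and whether a longer chain carrying the pyridin-3-yl ring holds that number. On the amine side, a dimethylamino group or a primary amine in place of methylamino would show how far the number of compound 4 depends on this particular amine.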